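A few compounds are considered here, and "the series" means these few. Any claim that something is new, unique, unknown or untested is made for them only; others in the source may bear on it.

Measured in an ADME assay on BJ cells (Homo sapiens), read by MTT assay, with a stated time of 72 h; on this read-out lower numbers stand for stronger inhibition and higher numbers for weaker inhibition:
- compound 1 `CSc1ncnc2c1c(-c1ccoc1)cn2[C@@H]1O[C@H](CO)[C@@H](O)[C@H]1O`: 98800 nM
- compound 2 `CSc1ncnc2c1c(-c1cccs1)cn2[C@@H]1O[C@H](CO)[C@@H](O)[C@H]1O`: 96900 nM
- compound 3 `C#Cc1cn([C@@H]2O[C@H](CO)[C@@H](O)[C@H]2O)c2ncnc(SC)c12`: 68600 nM

Compound 1 stands level with the other two within the scatter. This is shown by a 1.0-fold lower number from compound 1 to compound 2 (0.01 log units; within the scatter) and a 1.4-fold lower number from compound 1 to compound 3 (0.16 log units; within the scatter). The remaining step, a 1.4-fold lower number from compound 2 to compound 3 (0.15 log units; within the scatter), also lies within the scatter. All three compounds carry methylsulfanyl, and all three steps exchange only the other group, the furan-3-yl of compound 1.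

Compound 4 `CNc1ncnc2c1c(-c1ccoc1)cn2[C@@H]1O[C@H](CO)[C@@H](O)[C@H]1O` keeps that furan-3-yl and the rest of the core of compound 1, but changes the group the series has so far held constant: methylamino in place of methylsulfanyl on an aromatic carbon. For the measured compounds named here, no measured step touches this group, so the data give no direct size or direction for the change. Going by the values given here, the steps above show only that one exchange elsewhere on the core left the read-out within the scatter, and they cannot be carried across to methylamino.

A modest move to a lower number is expected, held loosely and with a wide margin. The estimated step is a 2.0-fold lower number from compound 1 to compound 4 (0.30 log units; within the scatter). For compound 4 the expected value is 50000 nM, with an estimated range from 6000 nM to 130000 nM.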

Compound 4, half-maximal inhibitory concentration: 96300 nM
Compound 4: the middle estimate sits 1.9-fold (0.28 log units) below what was measured; low and high end bracket the measured number.
By their numbers in this assay, from the lowest: compounds 3, 4, 2 and 1 (each within the scatter of the next).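

Working notes on the series. In this assay, for the compounds shown here, the first exchange at this position, methylamino in place of methylsulfanyl, gives a 1.0-fold lower number from compound 1 to compound 4 (0.01 log units; within the scatter), so the two groups stand level on the core of compound 1 even though the entering group adds a hydrogen-bond donor and carries nitrogen in place of sulfur. The earlier steps shown here covered only the site that holds furan-3-yl, ethynyl or thiophen-2-yl, whereas this step shows that the site on the aromatic carbon next to the ring nitrogen can also be exchanged with the read-out staying within the scatter. Nothing available bears on the reason these two groups read alike.

The compounds shown leave open whether methylamino stays level with methylsulfanyl when thiophen-2-yl or ethynyl replaces furan-3-yl, since this position has been read only with furan-3-yl in place. They also leave open whether a free amine, a dimethylamino group, a methoxy group or a longer alkylamino chain at this position would give a step beyond the scatter.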